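Fluoro added to the urea aryl of compound 2

The source may report more compounds than this note shows. Statements on the series, on what has been measured and on what is new or still open speak of the compounds shown alone.

Measured in a functional assay on MDA-MB-231 cells (Homo sapiens) for cytotoxicity, read by MTT assay, with a stated time of 72 h; on this read-out lower numbers stand for stronger inhibition and higher numbers for weaker inhibition:
- compound 1, `CN(C)CCNc1nc(-c2ccc(NC(=O)Nc3ccc(F)cc3)cc2)nc2ccsc12`: 540 nM
- compound 2, `CCN(CC)CCCNc1nc(-c2ccc(NC(=O)Nc3ccccc3)cc2)nc2ccsc12`: 1230 nM

Compound 2 stands highest of the two numbers. The nearest is compound 1, whose number is lower, and that gap lies beyond the usual scatter. For the measured compounds named here, the two compounds differ in two places at once, the amine chain and the fluoro on the urea aryl, so no single-change step between measured compounds is available.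

Compound 3, `CCN(CC)CCCNc1nc(-c2ccc(NC(=O)Nc3ccc(F)cc3)cc2)nc2ccsc12`, is the next point. It differs from compound 2 by fluoro in place of hydrogen on an aromatic carbon. It thus carries the fluorinated urea aryl of compound 1 together with the amine chain of compound 2. Whether the lower number of compound 1 comes from the fluoro, from the chain, or from both cannot be told from the two values shown.

The step from compound 2 to compound 3 is expected to be a modest move toward a lower number, of the size a 1.5-fold lower number from compound 2 to compound 3 (0.19 log units; within the scatter), and it may not clear the scatter. For compound 3 the estimate in this assay is 800 nM, with a range from 350 nM to 1800 nM.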

Compound 3, half-maximal inhibitory concentration: 530 nM
Compound 3: the middle estimate sits 1.5-fold (0.18 log units) above what was measured; measured number inside the range.
By their numbers in this assay, from the lowest: compounds 3 and 1 (each within the scatter of the next); then compound 2.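

In this assay, for the compounds shown here, the single change on the urea aryl can now be read by itself: phenyl to 4-fluorophenyl, on the amine chain of compound 2, gives a 2.3-fold lower number from compound 2 to compound 3 (0.37 log units; beyond the scatter) and so clears the scatter. The other single change, (diethylamino)methyl in place of dimethylamino with the 4-fluorophenyl urea held constant, gives a 1.0-fold lower number from compound 1 to compound 3 (0.01 log units; within the scatter) and stays within the scatter, so this assay does not separate the two amine chains on that urea. Among the three compounds, the gap between compound 1 and compound 2 therefore goes with the fluoro rather than the chain, though no measurement at hand explains how the fluoro acts.

Open, as far as these compounds go, is whether the fluoro step holds on the dimethylamino chain of compound 1, and whether chloro or methoxy on the same aromatic carbon, para to a large group, moves the number as fluoro does. Also open, from the compounds shown here alone, is whether a longer chain ending in diethylamino keeps the number of compound 3 530 nM or shifts it.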